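Aryl variation on the semicarbazone of compound 1

The source may hold more compounds than are shown below. What is called first, only, known or untested is meant among the compounds shown, and "the series" means these compounds.

Measured compounds:
compound 1, `CN(C)CCn1cnnc1-c1cc(Oc2ccc(NC(=O)N/N=C/c3ccc(O)c(F)c3)cc2F)ccn1`, 2620 nM
compound 2, `CN(C)CCn1cnnc1-c1cc(Oc2ccc(NC(=O)N/N=C/c3cc(C(C)(C)C)cc(C(C)(C)C)c3O)cc2F)ccn1`, 590 nM
compound 3, `CN(C)CCn1cnnc1-c1cc(Oc2ccc(NC(=O)N/N=C/c3c(O)ccc4ccccc34)cc2F)ccn1`, 890 nM

In a functional assay on NCI-H460 cells (Homo sapiens) for cytotoxicity, read by MTT assay, with a stated time of 72 h (a higher number here means a weaker inhibitor, a lower number a stronger inhibitor), compound 1 gives the highest number of the three: compound 3 is the nearest with 890 nM, and compound 2 is the furthest with 590 nM. Going by the values given here, the one single-point step recorded here, a 2.9-fold lower number from compound 1 to compound 3 (0.47 log units; beyond the scatter), is beyond the scatter and runs downward. Compound 2 is not joined to compound 1 by a single-point step; its value simply sits below both others.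

Compound 4, `Cc1cc(/C=N/NC(=O)Nc2ccc(Oc3ccnc(-c4nncn4CCN(C)C)c3)c(F)c2)cc(C)c1O`, is unmeasured. 4-hydroxy-3,5-dimethylphenyl in place of 3-fluoro-4-hydroxyphenyl on a carbon with a double bond to nitrogen This is a change at the same carbon with a double bond to nitrogen as in the recorded step, and both other aryl variants, compound 2 and compound 3, give lower numbers than compound 1. A modest downward step is therefore expected, though a number no better than the scatter cannot be excluded since no variant with this exact group has been measured. The expected step is a 2.0-fold lower number from compound 1 to compound 4 (0.30 log units; within the scatter). Compound 4 is estimated at 1300 nM, with a range from 550 nM to 3000 nM.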

Compound 4, half-maximal inhibitory concentration: 2010 nM
Beside the measured number, compound 4's estimate is 1.5-fold (0.19 log units) below it, within the range that was stated.
By their numbers in this assay, from the lowest: compounds 2 and 3 (each within the scatter of the next); then compounds 4 and 1 (each within the scatter of the next).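

In this assay, 4-hydroxy-3,5-dimethylphenyl in place of 3-fluoro-4-hydroxyphenyl on a carbon with a double bond to nitrogen gives a 1.3-fold lower number from compound 1 to compound 4 (0.12 log units; within the scatter), so this aryl change, unlike the 2-hydroxynaphthalen-1-yl change, does not separate from compound 1. The comparison between the two new aryl groups does separate, with a 2.3-fold higher number from compound 3 to compound 4 (0.35 log units; beyond the scatter), which shows that the response at this position depends on the aryl group and is not shared by every replacement of 3-fluoro-4-hydroxyphenyl. No measurement available here accounts for the difference between these aryl groups.

Every aryl group shown carries a hydroxyl, so an aryl group with an amine or a methoxy group in its place would show whether the hydroxyl is needed. A 4-hydroxy-3-methylphenyl group would show what one methyl group gives on its own.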